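The source may report more compounds than this note shows. Statements on the series, on what has been measured and on what is new or still open speak of the compounds shown alone.

Series notes. In a functional assay on HeLa cells (Homo sapiens) for antiproliferative activity, read by sulforhodamine B assay (on this read-out higher numbers stand for weaker inhibition and lower numbers for stronger inhibition), compound 2 `C/C(=N\Nc1nc2ccccc2o1)c1ccccn1` gives 23 nM, the lowest of the three numbers recorded. Compound 3 `CCC/C(=N\Nc1nc2ccccc2o1)c1ccccn1` gives 153 nM, and compound 1 `C/C(=N\Nc1nc2ccccc2o1)c1nccnc1C` gives 1860 nM. Within the data shown here, the only single-point step on record is a 6.7-fold higher number from compound 2 to compound 3 (0.82 log units; beyond the scatter), a change on the saturated chain carbon rather than on the aromatic ring. Compound 4 `C/C(=N\Nc1nc2ccccc2o1)c1cnccn1` differs from compound 2 by pyrazin-2-yl in place of pyridin-2-yl on a carbon with a double bond to nitrogen. Among the measured compounds shown here, no measured step bears directly on this ring change. For the measured compounds named here, compound 1 carries a pyrazin-2-yl-type ring but also an added methyl, so its value set against compound 2 shows only that those two changes together sit far higher. A weakening is therefore expected, estimated as a 13-fold higher number from compound 2 to compound 4 (1.12 log units; beyond the scatter). Compound 4 is expected to give 300 nM, in the range 60 nM to 1500 nM.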

Compound 4, half-maximal inhibitory concentration: 690 nM
Compound 4: middle estimate off by 2.3-fold (0.36 log units), on the low side, and the stated range covers the measured number.
By their numbers in this assay, from the lowest: compound 2; then compound 3; then compound 4; then compound 1.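

In this assay, the ring on the carbon with a double bond to nitrogen now has a step of its own: pyrazin-2-yl in place of pyridin-2-yl gives a 30-fold higher number from compound 2 to compound 4 (1.48 log units; beyond the scatter). The methyl on the pyrazin-2-yl ring can also be read alone, since hydrogen in its place on an aromatic carbon gives a 2.7-fold lower number from compound 1 to compound 4 (0.43 log units; beyond the scatter). No measurement on hand gives a reason for either step.

Still open, from the compounds shown here alone, is how a methoxy or an amine on the pyridin-2-yl ring would read. Also open, going by these compounds, is whether the ethyl step on the saturated chain carbon carries over to the pyrazin-2-yl compounds.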